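A few compounds are considered here, and "the series" means these few. Any claim that something is new, unique, unknown or untested is made for them only; others in the source may bear on it.

Measured in an assay for inhibition of Nitric oxide synthase, inducible (Homo sapiens), read by scintillation counting, with a stated time of 30 min, tested at 1 mM; a higher number here means more inhibition at the concentration tested (going by the name of the read-out), a lower number less inhibition:
compound 1, `CNC(=S)NCCC(O)c1ccccc1N`: 20.7%
compound 2, `CCCNC(=S)NCCC(O)c1ccccc1N`: 31.1%
compound 3, `CNC(=S)NCCC(O)c1cc(OC)ccc1N`: 76.6%

Compound 3 stands highest of the three, its gaps to compound 2 and compound 1 both beyond the scatter. Compound 4, `CCCNC(=S)NCCC(O)c1cc(OC)ccc1N`, differs from compound 3 by ethyl in place of hydrogen on a saturated chain carbon bound to an amide-type nitrogen. For the measured compounds named here, the one measured step of the same kind is a number 10.4 percentage points higher from compound 1 to compound 2 (beyond the scatter), a modest rise. The other step, a number 55.9 percentage points higher from compound 1 to compound 3 (beyond the scatter), is of a different kind and only sets where compound 3 starts. Compound 4 is therefore expected to show a modest rise in this assay, a number 8.4 percentage points higher from compound 3 to compound 4 (within the scatter), though the read-out, a percentage, leaves limited room above compound 3. The estimate for compound 4 is 85%, with a range from 70% to 97%.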

Compound 4, a percentage reported as inhibition, at one concentration (the size of the read-out at that concentration, not a potency): 25.4%
Beside the measured number, compound 4's estimate is 59.6 percentage points above it, and the stated range ends above it.
By their numbers in this assay, from the lowest: compounds 1, 4 and 2 (each within the scatter of the next, the first and the last beyond it); then compound 3.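

With methoxy on the aromatic carbon, ethyl in place of hydrogen at this chain position gives a number 51.2 percentage points lower from compound 3 to compound 4 (beyond the scatter), so the rise seen without methoxy does not carry over: the same change on two cores in this assay, a number 10.4 percentage points higher (beyond the scatter) from compound 1 to compound 2 and a number 51.2 percentage points lower (beyond the scatter) from compound 3 to compound 4, 61.6 percentage points apart, beyond the scatter of two such steps Methoxy, in turn, gives a number 5.7 percentage points lower from compound 2 to compound 4 (within the scatter) when propylamino replaces methylamino, so its gain does not carry over either: the same change on two cores in this assay, a number 55.9 percentage points higher (beyond the scatter) from compound 1 to compound 3 and a number 5.7 percentage points lower (within the scatter) from compound 2 to compound 4, 61.6 percentage points apart, beyond the scatter of two such steps The two changes therefore do not add, and only compound 3, which joins methoxy with methylamino, stands high.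

On these data alone, whether an ethylamino group in place of methylamino would keep the number of compound 3 remains open. So does whether a chloro or hydroxy group in place of methoxy would show the same dependence on the chain.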